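The source may hold more compounds than are shown below. What is called first, only, known or untested is meant among the compounds shown, and "the series" means these compounds.

The two measured compounds share one core carrying a nitrile and an amino group. Compound 1 `COc1cc(C2C(C#N)=C(N)Oc3cc(Br)ccc32)cc(Br)c1OC` and compound 2 `N#CC1=C(N)Oc2c(ccc(N)c2N)C1c1cccc([N+](=O)[O-])c1` were both tested in a functional assay on T47D cells (Homo sapiens) for activation; on this read-out higher numbers stand for an effect only at larger amounts of compound and lower numbers for an effect already at smaller amounts. In this assay compound 1 gives 140000000 nM, the lowest of the two numbers, and compound 2 gives 390000000 nM, a gap that lies beyond the scatter of repeated runs.

Compound 3 `COc1cc(C2C(C#N)=C(N)Oc3cc(Cl)ccc32)cc(Br)c1OC` is the next compound and has not yet been measured. Relative to compound 1 the change is chloro in place of bromo on an aromatic carbon, with everything else kept. No comparison of this kind exists among the measured compounds, so the size of the effect is open. On the basis of compound 1 at 140000000 nM the step from compound 1 to compound 3 is expected to be small, a 1.1-fold higher number from compound 1 to compound 3 (0.03 log units; within the scatter), with no direction beyond the scatter. For compound 3 the estimated value is 150000000 nM, within a range from 60000000 nM to 400000000 nM.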

Compound 3, half-maximal effective concentration: 160000000 nM
For compound 3 the middle estimate is 1.1-fold (0.03 log units) below the measured one; the range from low to high includes it.
By their numbers in this assay, from the lowest: compounds 1 and 3 (each within the scatter of the next); then compound 2.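

Chloro in place of bromo on an aromatic carbon of the fused two-ring system gives a 1.1-fold higher number from compound 1 to compound 3 (0.06 log units; within the scatter) in this assay. Among these compounds, this is the first comparison in the set that isolates a single place, and it shows that on this read-out the two halogens at this position cannot be told apart, even though the number of heavy atoms, hydrogen-bond donors and acceptors and the net charge stay the same across the change. No measurement available here bears on why the exchange reads this way.

On these data alone, it remains open whether fluoro, a carboxylic acid or a longer chain at this position would shift the number beyond the scatter. Also open, as far as these compounds go, is whether chloro in place of the bromo that compound 1 and compound 3 share on their other aromatic ring would read the same.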